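The compounds below may be only part of what the source reports. "The series", "measured", "known", "first", "only" and "open" are said of these compounds alone.

Compound 1 `CCCCCC/C(=N\OCCC)c1cc(OC)c2c(c1OC)C(=O)C=CC2=O` is one of three compounds tested in a functional assay on L1210 cells (Mus musculus) for antiproliferative activity; a lower number here means that less compound is needed, a higher number that more compound is needed for the effect. In this assay compound 1 gives 0.166 ug/mL. Compound 2 `CCCO/N=C/c1cc(OC)c2c(c1OC)C(=O)C=CC2=O` gives 0.107 ug/mL in this assay, and compound 3 `CCCCCCCCCO/N=C/c1cc(OC)c2c(c1OC)C(=O)C=CC2=O` gives 0.19 ug/mL. Of the three numbers, that of compound 1 is the second highest, but its gaps to compound 3 and to compound 2 are both within the scatter. Compound 4 `CCCCCCCCCO/N=C(\CCCCCC)c1cc(OC)c2c(c1OC)C(=O)C=CC2=O` is not yet measured. Compared with compound 1 it shows (hexyl in place of hydrogen on a saturated chain carbon, three bonds along the chain from an oxygen on an unsaturated carbon). The same change has been measured once, as the step of a 1.8-fold higher number from compound 2 to compound 3 (0.25 log units; within the scatter), which stayed within the scatter. On that basis only a small upward shift, or none beyond the scatter, is expected for compound 4, whose estimated step is a 1.5-fold higher number from compound 1 to compound 4 (0.18 log units; within the scatter) and whose expected value is 0.25 ug/mL with a range from 0.12 ug/mL to 0.5 ug/mL.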

Compound 4, concentration for half-maximal effect: 1.15 ug/mL
Beside the measured number, compound 4's estimate is 4.6-fold (0.66 log units) below it, and the stated range ends below it.
By their numbers in this assay, from the lowest: compounds 2, 1 and 3 (each within the scatter of the next); then compound 4.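

In this assay, hexyl in place of hydrogen at this saturated chain carbon is not a change that can be ignored on every core: on the core of compound 1 it gives a 6.9-fold higher number from compound 1 to compound 4 (0.84 log units; beyond the scatter). More compound is now needed for the effect, so a small step on one core does not carry over to another. The size of this change depends on the core that carries it: the same change on two cores in this assay, a 1.8-fold higher number (0.25 log units; within the scatter) from compound 2 to compound 3 and a 6.9-fold higher number (0.84 log units; beyond the scatter) from compound 1 to compound 4, 3.9-fold (0.59 log units) apart, beyond the scatter of two such steps

With only propyl and nonyl at this place, the compounds shown leave open how the number moves at intermediate chains such as butyl. Also open, from the compounds shown here alone, is whether a chain ending in an amine or a carboxylic acid would behave the same way.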